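Series notes: from compound 1 to compound 4

The compounds below may be only part of what the source reports. "The series", "measured", "known", "first", "only" and "open" are said of these compounds alone.

Measured so far:
compound 1, `C=CCOc1c(C)c(C)c2c(c1C)CCC(C)(COc1ccc(/C=C3\SC(=O)NC3=O)cc1OC)O2`, 34%
compound 2, `C=CCOc1c(C)c(C)c2c(c1C)CCC(C)(COc1cccc(/C=C3\SC(=O)NC3=O)c1)O2`, 84%
compound 3, `CC(C)=CCOc1c(C)c(C)c2c(c1C)CCC(C)(COc1ccc(/C=C3\SC(=O)NC3=O)cc1-c1ccc(F)cc1)O2`, 87%

In a functional assay on MCF7 cells (Homo sapiens), tested at 2.5 uM (a lower number here means a stronger effect, a higher number a weaker effect of the compound at the concentration tested), compound 1 gives 34%, the lowest of the three numbers. Compound 2 gives 84% and compound 3 gives 87%, each of them beyond the scatter above compound 1. Compound 4, `C=CCOc1c(C)c(C)c2c(c1C)CCC(C)(COc1ccc(/C=C3\SC(=O)NC3=O)cc1OCC)O2`, has not been measured. It differs from compound 1 in a single place: methyl in place of hydrogen on a saturated chain carbon bound to an oxygen on an aromatic ring. Going by the values given here, no single-change step between measured compounds is available for comparison, so the size of this step in this assay is open. A small step toward a weaker effect is expected, possibly none beyond the scatter. For compound 4 the estimate is 42%, within 25% to 65%, corresponding to an expected step of a number 8 percentage points higher from compound 1 to compound 4 (within the scatter).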

Compound 4, a percentage reported as activity, at one concentration (the size of the read-out at that concentration, not a potency): 107%
The estimate for compound 4 lay 65 percentage points below the measured number; the whole stated range lies below it.
By their numbers in this assay, from the lowest: compound 1; then compounds 2 and 3 (each within the scatter of the next); then compound 4.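

In this assay, going from methoxy to ethoxy gives a number 73 percentage points higher from compound 1 to compound 4 (beyond the scatter) and so shows that this position is highly sensitive to size of the substituent in this series: one added methyl on a saturated chain carbon bound to an oxygen on an aromatic ring is enough to lose the effect of compound 1. The earlier compounds shown here differ in more than one place and could not isolate this. Nothing on hand accounts for the size of this step.

On these data alone, whether a hydroxyl, a fluorine or a longer chain such as propoxy at this place would keep the effect stays open. As far as these compounds go, whether the step would be of the same size on a different ether elsewhere on the shared core is also open.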